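An Oxetan-3-yl Amide in Place of a Larger Ring

The source may report more compounds than this note shows. Statements on the series, on what has been measured and on what is new or still open speak of the compounds shown alone.

Measured compounds:
Compound 1, `CC(C)c1noc(N2CCN(C(=O)[C@@H]3CCCN(S(=O)(=O)c4ccc(S(=O)(=O)C(C)C)cc4)C3)CC2)n1`: > 10000 nM
Compound 2, `CCN(CC)S(=O)(=O)c1ccc(S(=O)(=O)N2CCC[C@@H](C(=O)N[C@@H]3CCN(C(=O)OC(C)(C)C)C3)C2)cc1`: > 10000 nM
Compound 3, `CCOC(=O)N1CCC[C@H](S(=O)(=O)c2ccc(S(=O)(=O)N(CC)CC)cc2)C1`: > 10000 nM

All three values come from a functional assay on MIA PaCa-2 cells (Homo sapiens) for inhibition, read by MTT assay, with a stated time of 3 days; a lower number here means a stronger inhibitor, a higher number a weaker inhibitor. The value for compound 1 is a limit of the assay, not a number. The value for compound 2 is likewise a limit. The value for compound 3 is a limit as well. Among the measured compounds shown here, compound 2 therefore stands where every compound so far stands: at the limit of > 10000 nM in this assay, at which 3 of the 3 values shown sit. For the measured compounds named here, no two measured compounds differ in a single place, so no step between measured compounds can be sized, and the three values show only that none of them reached a measurable number.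

Compound 4, `CCN(CC)S(=O)(=O)c1ccc(S(=O)(=O)N2CCC[C@@H](C(=O)NC3COC3)C2)cc1`, is not yet measured. It differs from compound 2 in one place: oxetan-3-yl in place of 1-(tert-butoxycarbonyl)pyrrolidin-3-yl on an amide-type nitrogen. With every measured compound sitting at the same limit, there is no basis in these data for expecting compound 4 to move in either direction beyond the scatter; the step is expected to be a step that the limit leaves unreadable from compound 2 to compound 4. In this assay compound 4 is estimated at 20000 nM. The lower end of that estimate for compound 4 is 5000 nM. The upper end of that estimate for compound 4 is expected to be 100000 nM.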

Compound 4, half-maximal inhibitory concentration: > 10000 nM
Compound 4 was reported as a limit (the forecaster's own chance of this, stated with the estimate: 85%); the middle value lies beyond the limit too.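

In this assay compound 2 and compound 4 both sit at a limit, not at a number, so the swap of 1-(tert-butoxycarbonyl)pyrrolidin-3-yl for oxetan-3-yl cannot be sized between them. The compounds shown leave open how strongly any of them inhibits, and what would bring a measurable value, since all share one reading: the limit of > 10000 nM in this assay, at which 4 of the 4 values shown sit.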